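Trifluoromethyl added to two fluorophenyl dienones

The source may hold more compounds than are shown below. What is called first, only, known or untested is meant among the compounds shown, and "the series" means these compounds.

Compound 1 `CC1=CCCC(C)(C)C1/C=C/C(=O)/C=C/c1ccccc1F` and compound 2 `CC1=CCCC(C)(C)C1/C=C/C(=O)/C=C/c1cc(C(F)(F)F)ccc1F` share one core; compound 3 `CC1=C(/C=C/C(=O)/C=C/c2cccc(F)c2)C(C)(C)CCC1O` and compound 4 `CC1=C(/C=C/C(=O)/C=C/c2cc(F)cc(C(F)(F)F)c2)C(C)(C)CCC1O` share another. The difference between the two cores is not broken down here. In a functional assay on CWR22R cells (Homo sapiens) for cytotoxicity, read by MTT assay, with a stated time of 72 h (on this read-out higher numbers stand for weaker inhibition and lower numbers for stronger inhibition), compound 1 gives 9400 nM, compound 2 gives 3500 nM, and compound 3 gives 5600 nM. The step of a 2.7-fold lower number from compound 1 to compound 2 (0.43 log units; beyond the scatter) comes from trifluoromethyl in place of hydrogen on an aromatic carbon. The same kind of change leads from compound 3 to compound 4: trifluoromethyl in place of hydrogen on an aromatic carbon. The two places are not the same: in compound 2 the new group sits para to a fluoro group, in compound 4 it sits meta to a fluoro group, so the second change is of the same kind, not the same. Among the measured compounds shown here, compound 4 is expected to show a step of a 2.0-fold lower number from compound 3 to compound 4 (0.30 log units; within the scatter), a little smaller than the earlier one, because only the single step of a 2.7-fold lower number from compound 1 to compound 2 (0.43 log units; beyond the scatter) supports it and the placing differs. The estimate for compound 4 in this assay is 2800 nM, with a range from 1200 nM to 7000 nM.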

Compound 4, half-maximal inhibitory concentration: 2400 nM
For compound 4 the middle estimate is 1.2-fold (0.07 log units) above the measured one; low and high end bracket the measured number.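

In this assay trifluoromethyl in place of hydrogen on an aromatic carbon again goes with a lower number, giving a 2.3-fold lower number from compound 3 to compound 4 (0.37 log units; beyond the scatter) on the second core. Set beside the earlier step, the change keeps its size from one core to the other: the same change on two cores in this assay, a 2.7-fold lower number (0.43 log units; beyond the scatter) from compound 1 to compound 2 and a 2.3-fold lower number (0.37 log units; beyond the scatter) from compound 3 to compound 4, 1.2-fold (0.06 log units) apart, within the scatter of two such steps. This shows that the step carried over in these two pairs, even though the new group does not stand in the same place relative to the fluoro group in compound 2 and compound 4, but two pairs cannot establish a rule for the series, and they do not separate the effect of the core from that of the placing.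

The compounds shown leave open whether a different group on the same aromatic carbon, such as a methoxy group, an amine or a carboxylic acid, would give a step of similar size. They also leave open whether trifluoromethyl would give such a step at other places on the ring.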